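The compounds below may be only part of what the source reports. "The series", "measured", "known", "first", "only" and "open" are said of these compounds alone.

Measured so far:
compound 1 `CS(=O)(=O)NNc1nonc1/C(=N/O)Nc1ccc(F)c(Br)c1` — in an assay on HeLa cells for inhibition of Indoleamine 2,3-dioxygenase 1 (Homo sapiens), read by spectrophotometry, with a stated time of 24 h (a lower number here means that less compound is needed, a higher number that more compound is needed for the effect), compound 1 sits at a limit of the assay, > 800 nM.
compound 2 `[O-][S+]1CC(Nc2nonc2/C(=N/O)Nc2ccc(F)c(Br)c2)C1` — in this assay compound 2 gives 79 nM.
compound 3 `CCNS(=O)(=O)CCNc1nonc1/C(=N/O)Nc1ccc(F)c(Br)c1` — in this assay compound 3 gives 41 nM.

Compound 2 holds the higher of the two numbers in this assay; its nearest neighbour is compound 3, with a 1.9-fold lower number from compound 2 to compound 3 (0.28 log units; within the scatter). The remaining value, that of compound 1, is only a limit (the limit of > 800 nM in this assay, at which 1 of the 3 values shown sits).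

Compound 4 `O=S(=O)(CCNc1nonc1/C(=N/O)Nc1ccc(F)c(Br)c1)NO` is not yet measured. It differs from compound 2 thus: a group of 7 heavy atoms (2 carbon, 1 nitrogen, 3 oxygen, 1 sulfur; no ring) in place of a group of 5 heavy atoms (3 carbon, 1 oxygen, 1 sulfur; one four-membered non-aromatic ring with 1 hetero atom), on a nitrogen on an aromatic ring.

Going by the values given here, three measured steps bear on this. A ring-to-chain exchange on the same nitrogen was already seen in a 1.9-fold lower number from compound 2 to compound 3 (0.28 log units; within the scatter). Both the ring compound and the open-chain sulfonamide leave the limit far behind: an at least 10-fold lower number from compound 1 to compound 2 (1.00 log units; beyond the scatter) and an at least 19-fold lower number from compound 1 to compound 3 (1.29 log units; beyond the scatter). The change to compound 4 is of the same kind as the step to compound 3, so in this assay no step beyond the scatter is expected, at most a slightly lower number. Compound 4 is therefore estimated at 60 nM, with a range of 25 nM to 160 nM, which means an expected step of a 1.3-fold lower number from compound 2 to compound 4 (0.12 log units; within the scatter).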

Compound 4, half-maximal effective concentration: > 800 nM
Compound 4 gave a limit, no number (the forecaster's own chance of this, stated with the estimate: 5%); middle value at least 13-fold (1.12 log units) from the limit.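

In this assay compound 4 gives only a limit, > 800 nM, and compound 1 also stands at a limit, so the step between these two cannot be read: the limit of > 800 nM in this assay, at which 2 of the 4 values shown sit.

Exchanging the ring for an open chain on this nitrogen therefore has no uniform outcome, since an at least 10-fold higher number from compound 2 to compound 4 (1.00 log units; beyond the scatter) is beyond the scatter, while compound 3 goes against any general loss on opening the ring. Going by these compounds alone, the sulfonamide nitrogen, not varied among the earlier compounds, also matters, as hydroxy in place of ethyl gives an at least 19-fold higher number from compound 3 to compound 4 (1.29 log units; beyond the scatter).

As far as these compounds go, it remains open whether this loss belongs to hydroxy alone or to other replacements of ethyl on the sulfonamide nitrogen, such as methoxy or a propyl group. From the compounds shown here alone, the effect of a longer chain in place of 2-(ethylsulfamoyl)ethyl also remains open.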